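This account rests on a few compounds, and the source may have more. Where it says the series, first, only, none or still open, it means among the compounds named here.

In an ADME assay on MT4 cells (Homo sapiens) for cytotoxicity, read by MTT assay, with a stated time of 4 days (on this read-out higher numbers stand for lower toxicity in this test and lower numbers for higher toxicity in this test), compound 2 `Cc1cc(C#N)cc(C)c1Oc1ccnc(S(=O)(=O)CC(=O)Nc2ccc(Cl)cc2)n1` gives 16600 nM, and compound 1 `Cc1cc(C#N)cc(C)c1Oc1ccnc(S(=O)(=O)CC(=O)Nc2ccccc2Cl)n1` gives 12500 nM; the two values lie within the scatter of each other. Compound 3 `Cc1cc(C#N)cc(C)c1Oc1ccnc(S(=O)(=O)CC(=O)Nc2ccc([N+](=O)[O-])cc2)n1` differs from compound 2 by nitro in place of chloro on an aromatic carbon. Within the data shown here, the only measured step, a 1.3-fold higher number from compound 1 to compound 2 (0.12 log units; within the scatter), replaces one chlorophenyl with another on the amide-type nitrogen and bears only loosely on this change; no measured step swaps chloro for nitro. With that single step within the scatter, no step beyond the scatter is expected for a 1.1-fold lower number from compound 2 to compound 3 (0.04 log units; within the scatter). Compound 3 is therefore estimated at 15000 nM, with a range from 7000 nM to 35000 nM.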

Compound 3, half-maximal cytotoxic concentration: 59600 nM
Compound 3: middle estimate off by 4.0-fold (0.60 log units), on the low side, and the stated range ends below it.
By their numbers in this assay, from the lowest: compounds 1 and 2 (each within the scatter of the next); then compound 3.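

In this assay nitro in place of chloro gives a 3.6-fold higher number from compound 2 to compound 3 (0.56 log units; beyond the scatter) and 4-nitrophenyl in place of 2-chlorophenyl gives a 4.8-fold higher number from compound 1 to compound 3 (0.68 log units; beyond the scatter) on the same read-out, pointing to lower toxicity in this test for compound 3. The group at this place can therefore move the number beyond the scatter, which the step between the two chlorophenyl compounds did not show. No evidence on the origin of this difference is at hand. Open, as far as these compounds go, is whether this holds for other groups at this place, such as an amine or a carboxylic acid. Also open, from the compounds shown here alone, is how nitro behaves in the place held by chloro in compound 1.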